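Series notes: amide benzyl swap from compound 3 to compound 4

A few compounds are considered here, and "the series" means these few. Any claim that something is new, unique, unknown or untested is made for them only; others in the source may bear on it.

The shared core carries a secondary amine on one side and an amide on the other. Compound 1 `C[C@@H](CO)Nc1nc(C(=O)NCc2ccc(F)cc2)c(O)c2ncccc12` is the hydroxylated member and in a functional assay on HCT-116 cells (Homo sapiens) for cytotoxicity, read by MTT assay, with a stated time of 72 h (a lower number here means a stronger inhibitor, a higher number a weaker inhibitor), compound 1 gives "not determined" (no result reported). Compound 2 `C[C@@H](Nc1c(C(=O)NCc2ccc(F)cc2)nc(Br)c2cccnc12)c1ccccc1` carries a bromine on the core and a 4-fluorobenzyl amide; in this assay compound 2 returns only a limit of the assay, > 20000 nM. Compound 3 `N[C@H]1CC[C@H](Nc2c(C(=O)NCc3ccccn3)nc(Br)c3cccnc23)CC1` keeps the bromine and pairs a trans-diaminocyclohexyl amine with a (pyridin-2-yl)methyl amide; in this assay compound 3 gives "not determined" (no result reported). Compound 3 therefore stands without a number of its own, and the only quantitative anchor in the set is the limit described by the limit of > 20000 nM in this assay, at which 1 of the 3 values shown sits.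

Compound 4 `N[C@H]1CC[C@H](Nc2c(C(=O)NCc3ccc(F)cc3)nc(Br)c3cccnc23)CC1` differs from compound 3 in one place: 4-fluorophenyl in place of pyridin-2-yl on a saturated chain carbon bound to an amide-type nitrogen The change removes the hydrogen-bond acceptor of the departing ring and brings in a fluorine instead. For the measured compounds named here, no measured pair here spans this change, so the size of the step in this assay cannot be read from the data; the expectation is no step beyond the scatter, with weak potency the likelier outcome given that compound 2, which shares the 4-fluorobenzyl amide, sits at the limit > 20000 nM.

Compound 4 is expected to give about 15000 nM in this assay, within a range from 3000 nM to 40000 nM.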

Compound 4, half-maximal inhibitory concentration: 7000 nM
The estimate for compound 4 lay 2.1-fold (0.33 log units) above the measured number; measured number inside the range.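

Compound 4 gives 7000 nM in this assay, the first entry in the set that is a number rather than a limit. With the bromine and the 4-fluorobenzyl amide held, 4-aminocyclohexyl in place of 1-phenylethyl on a nitrogen on an aromatic ring gives an at least 2.8-fold lower number from compound 2 to compound 4 (0.45 log units; beyond the scatter), so the group on that nitrogen moves the read-out while the amide stays fixed. This step is a bound and not a true size, since one end of it rests on compound 2, whose entry is only a limit of the assay: the limit of > 20000 nM in this assay, at which 1 of the 4 values shown sits.

For the compounds shown here, the change from pyridin-2-yl to 4-fluorophenyl on a saturated chain carbon bound to an amide-type nitrogen cannot be read, as compound 3 holds no single number in this assay, and the series gives no other pair for it. Also open, on these data alone, is whether a plain benzyl amide in place of the 4-fluorobenzyl amide, or a carboxylic acid in place of the amine of the 4-aminocyclohexyl group, would shift the number set by compound 4.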